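The source may report more compounds than this note shows. Statements on the series, on what has been measured and on what is new or still open speak of the compounds shown alone.

Compound 1 `CCCCCCCCN(C)C(=O)Cn1cc(Cc2cnc(=O)n(CC(=O)NCCO)c2)c(=O)nc1SCc1ccc(F)cc1` gives 68% in a functional assay on a cell-free system (plasma) for inhibition of platelet-activating factor acetylhydrolase (Homo sapiens), tested at 100 nM; on this read-out higher numbers stand for more inhibition at the one concentration tested (going by the name of the read-out) and lower numbers for less inhibition. Compound 2 `CCCCCCCCN(C)C(=O)Cn1cc(Cc2cnc(=O)n(CC(=O)N3CCOCC3)c2)c(=O)nc1SCc1ccc(F)cc1` gives 64% in this assay, the smaller of the two numbers shown, yet the only step measured so far, a number 4 percentage points lower from compound 1 to compound 2 (within the scatter), stays within the scatter. Compound 3 `CCCCCCCCN(C)C(=O)Cn1cc(Cc2cnc(=O)n(CC(=O)N3CCNC(=O)C3)c2)c(=O)nc1SCc1ccc(F)cc1` differs from compound 2 in one place: 3-oxopiperazin-1-yl in place of morpholin-4-yl on a carbonyl carbon. For the measured compounds named here, that single earlier step is the only one bearing on this change, and it moved nothing beyond the scatter, so a step of a number 1 percentage points lower from compound 2 to compound 3 (within the scatter) is expected, with no shift beyond the scatter. Compound 3 is estimated at 63%, within a range from 48% to 76%.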

Compound 3, a percentage reported as inhibition, at one concentration (the size of the read-out at that concentration, not a potency): 80%
The estimate for compound 3 lay 17 percentage points below the measured number; measured number outside the range, above it.
By their numbers in this assay, from the lowest: compounds 2 and 1 (each within the scatter of the next); then compound 3.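

The carbonyl-linked group at this position can change the result in this assay after all: 3-oxopiperazin-1-yl gives a clear gain over morpholin-4-yl (a number 16 percentage points higher from compound 2 to compound 3 (beyond the scatter)) and over (2-hydroxyethyl)amino (a number 12 percentage points higher from compound 1 to compound 3 (beyond the scatter)). The two earlier groups stayed within the scatter of each other, so not every swap here matters. Nothing measured explains the gain.

Going by these compounds, it remains open whether the gain depends on the ring carbonyl or the ring hydrogen-bond donor of 3-oxopiperazin-1-yl. Piperazin-1-yl, which lacks that carbonyl, and 4-methyl-3-oxopiperazin-1-yl, which has a methyl group on the ring amide nitrogen, would help separate the two.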